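The source may hold more compounds than are shown below. What is called first, only, known or untested is meant among the compounds shown, and "the series" means these compounds.

Working notes on the series. Compound 1 `CCCc1ccc(-c2ccc(N(C[C@@H](N)[C@@H](C)CC)C(=O)[C@@H]3C[C@H]3c3ccccc3)cc2)cc1` gives 61 nM in a functional assay for agonist activity at G protein-coupled receptor 88 (Homo sapiens), read by HTRF and cAMP accumulation; on this read-out lower numbers stand for an effect already at smaller amounts and higher numbers for an effect only at larger amounts of compound. Compound 2 `CC[C@H](C)[C@H](N)CN(C(=O)[C@@H]1C[C@H]1c1ccccc1)c1ccc(-c2ccc(OC(F)(F)F)cc2)cc1` gives 170 nM in this assay, and compound 3 `CC[C@H](C)[C@H](N)CN(C(=O)[C@@H]1C[C@H]1c1ccccc1)c1ccc(-c2ccc(COC(C)(C)C)cc2)cc1` gives 280 nM in this assay. Compound 3 thus carries the highest of the three numbers; its nearest neighbour is compound 2, with a gap that stays within the scatter (a 1.6-fold higher number from compound 2 to compound 3 (0.22 log units; within the scatter)), while the gap to compound 1 goes beyond it (a 4.6-fold higher number from compound 1 to compound 3 (0.66 log units; beyond the scatter)).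

Compound 4 `CC[C@H](C)[C@H](N)CN(C(=O)[C@@H]1C[C@H]1c1ccccc1)c1ccc(-c2ccc(NC(C)=O)cc2)cc1` differs from compound 3 in one place: acetamido in place of (tert-butoxy)methyl on an aromatic carbon. The measured steps that bear on this position are all exchanges of the group on the same aromatic carbon. a 2.8-fold higher number from compound 1 to compound 2 (0.45 log units; beyond the scatter) and a 4.6-fold higher number from compound 1 to compound 3 (0.66 log units; beyond the scatter) both move the number upward by a modest amount, while a 1.6-fold higher number from compound 2 to compound 3 (0.22 log units; within the scatter) stays within the scatter. Three compounds at this position leave the direction for an acetamido group open; the two departures from propyl so far both raised the number, and nothing measured resembles the incoming group. In this assay the expected step is therefore small, most likely a modest rise or none beyond the scatter, with wide uncertainty. For compound 4 the estimate in this assay is 400 nM, with a range of 150 nM to 1200 nM. The expected step is a 1.4-fold higher number from compound 3 to compound 4 (0.15 log units; within the scatter).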

Compound 4, half-maximal effective concentration: 5500 nM
Estimate against measurement, compound 4: 14-fold (1.14 log units) below; the whole stated range lies below it.
By their numbers in this assay, from the lowest: compound 1; then compounds 2 and 3 (each within the scatter of the next); then compound 4.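

In this assay this position proves far less forgiving than the first three compounds indicated: acetamido brings a 20-fold higher number from compound 3 to compound 4 (1.29 log units; beyond the scatter) and, read against the other groups, a 32-fold higher number from compound 2 to compound 4 (1.51 log units; beyond the scatter) and a 90-fold higher number from compound 1 to compound 4 (1.96 log units; beyond the scatter), all large steps, whereas the exchanges among propyl, trifluoromethoxy and (tert-butoxy)methyl stayed modest or within the scatter. Compound 4 is the only one of the four whose group on this aromatic carbon carries a hydrogen-bond donor, but with one such compound that feature cannot be separated from the other differences between acetamido and (tert-butoxy)methyl, namely the heavy-atom count and the double bond outside the aromatic rings. No available evidence bears on what lies behind this rise.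

Still open, going by these compounds, is which part of acetamido goes with the high number, the amide hydrogen or the carbonyl; a methylated amide, a simple amine, a ketone or a carboxylic acid on the same aromatic carbon would help to separate them. Within the data shown here, also open is whether a longer chain than propyl would hold or lower the number, since propyl is the only plain alkyl group in this set.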